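A few compounds are considered here, and "the series" means these few. Any claim that something is new, unique, unknown or untested is made for them only; others in the source may bear on it.

Compound 1 `c1ccc(Cn2cnc3c(Nc4ccccc4)ncnc32)cc1`: 0%
Compound 2 `CN(C)c1ncnc2c1ncn2Cc1cccc([N+](=O)[O-])c1`: 17%
Compound 3 `CN(C)c1ncnc2c1ncn2Cc1cccc(C#N)c1`: 17%

All three measured compounds were tested in a functional assay on the whole organism for inhibition, with Rattus norvegicus as the target, in the maximal electroshock model, at a dose of 25 mg/kg by the intraperitoneal route; on this read-out lower numbers stand for less inhibition and higher numbers for more inhibition at the one dose given (going by the name of the read-out). In this assay compound 1 gives 0%, compound 2 gives 17% and compound 3 gives 17%. Compound 3 therefore stands level with compound 2 at the digits shown, and the two together are the highest of the three numbers, while compound 1 lies lower by a gap that is beyond the scatter. Among the compounds with values here, only one pair of measured compounds differs in a single place, and that step, no change at the digits printed from compound 2 to compound 3 (within the scatter), brought no change beyond the scatter.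

Compound 4 `CN(C)c1ncnc2c1ncn2Cc1cccc(O)c1` is the compound not yet measured. It differs from compound 3 in one place: hydroxy in place of cyano on an aromatic carbon. Within the data shown here, no measured compound carries a hydroxy group on this ring, so no measured step speaks directly to this change; the one flat step, cyano in place of nitro, is the nearest guide and suggests that the group at this place does not move the read-out much. The expected step from compound 3 to compound 4 is therefore small, a number 2 percentage points lower from compound 3 to compound 4 (within the scatter), with a wide range to allow for the lack of direct precedent. Compound 4 is estimated to give 15% in this assay, expected between 0% and 35%.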

Compound 4, a percentage reported as inhibition, in the whole organism at one dose (the size of the read-out at that dose, not a potency): 0%
Estimate against measurement, compound 4: 15 percentage points above; measured number inside the range.
By their numbers in this assay, from the lowest: compounds 1 and 4 (each within the scatter of the next); then compounds 2 and 3 (each within the scatter of the next).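

In this assay the group on this aromatic carbon turns out not to be interchangeable: putting hydroxy in place of cyano brings a number 17 percentage points lower from compound 3 to compound 4 (beyond the scatter) and putting hydroxy in place of nitro brings a number 17 percentage points lower from compound 2 to compound 4 (beyond the scatter), so the flat step between the nitro and cyano compounds does not extend to every group here. This is the first change at this place, meta to a large group, to move the read-out beyond the scatter, and it brings in a hydrogen-bond donor where cyano carried none, although nothing shown ties the fall to that donor. No measurement at hand accounts for the fall seen with this change.

As far as these compounds go, it remains open whether a methoxy group, an amine or a carboxylic acid on this aromatic carbon would read like hydroxy or like cyano and nitro. Also open, from the compounds shown here alone, is whether hydroxy would bring a similar step on the core of compound 1, and how these compounds would compare at other doses, as the read-out reports a single dose and not a potency.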